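A benzyl swap among closely matched amides

The source may report more compounds than this note shows. Statements on the series, on what has been measured and on what is new or still open speak of the compounds shown alone.

In a functional assay on Huh-7 cells (Homo sapiens) for inhibition, read by MTT assay, with a stated time of 48 h (on this read-out lower numbers stand for stronger inhibition and higher numbers for weaker inhibition), compound 1 (`COc1ccc2c(=O)c(/C=C/C(=O)Nc3cc(C)ccc3C)coc2c1`) gives 11100 nM and compound 2 (`COc1ccc2c(=O)c(/C=C/C(=O)NCc3cccc(F)c3)coc2c1`) gives 10100 nM while compound 3 (`COc1ccc(CNC(=O)/C=C/c2coc3cc(OC)ccc3c2=O)cc1`) gives 7570 nM on the same shared core. Compound 3 does not stand clearly apart from either neighbour, as both steps to it lie within the scatter (a 1.5-fold lower number from compound 1 to compound 3 (0.17 log units; within the scatter)) and (a 1.3-fold lower number from compound 2 to compound 3 (0.13 log units; within the scatter)).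

Compound 4 (`COc1ccc2c(=O)c(/C=C/C(=O)NCc3ccc(F)cc3F)coc2c1`) keeps that core and the amide but has 2,4-difluorophenyl in place of 4-methoxyphenyl on a saturated chain carbon bound to an amide-type nitrogen. The same difference can be read as 4-methoxybenzyl to 2,4-difluorobenzyl.

The closest measured precedent is the change from 3-fluorophenyl to 4-methoxyphenyl at this place (a 1.3-fold lower number from compound 2 to compound 3 (0.13 log units; within the scatter)). The wider replacement of 2,5-dimethylphenyl by 3-fluorobenzyl also stayed small (a 1.1-fold lower number from compound 1 to compound 2 (0.04 log units; within the scatter)). Going by the values given here, no measured compound carries two fluorines, so this precedent is only partial. From the compounds shown here alone, on these steps, no change beyond the scatter is expected in this assay and the direction remains open.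

The expected step is a 1.3-fold higher number from compound 3 to compound 4 (0.10 log units; within the scatter) and it remains only an estimate. For compound 4 the estimated value is 9500 nM with an expected range from 5000 nM to 18000 nM in this series.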

Compound 4, half-maximal inhibitory concentration: > 100000 nM
Compound 4 gave a limit, no number; the forecaster's own chance of this, stated with the estimate: 5%; at least 10-fold (1.02 log units) between middle value and limit.
By their numbers in this assay, from the lowest: compounds 3, 2 and 1 (each within the scatter of the next). At a limit, above all of these: compound 4.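

The place on the saturated chain carbon bound to the amide-type nitrogen had looked indifferent to its group, since every earlier step stayed within the scatter. With 2,4-difluorophenyl it no longer does, and all three steps to compound 4 lie beyond the scatter (an at least 13-fold higher number from compound 3 to compound 4 (1.12 log units; beyond the scatter)) (an at least 9.9-fold higher number from compound 2 to compound 4 (0.99 log units; beyond the scatter)) (an at least 9.0-fold higher number from compound 1 to compound 4 (0.95 log units; beyond the scatter)), so the series now holds one clear break. A single fluorine on the ring does not bring this with it, as compound 2, with 3-fluorophenyl, gives 10100 nM in this assay. For compound 4 the reading is a limit and not a number: the limit of > 100000 nM in this assay, at which 1 of the 4 values shown sits.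

The compounds shown cannot say how far compound 4 lies beyond that limit, or whether the break goes with the pair of fluorines or with where they sit on the ring, as they hold only one ring of this kind. They also leave open how the series would respond to a phenethyl group on the amide nitrogen, or to a benzyl ring carrying a chlorine or an amine.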